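Dropping the aromatic chloro: what happens to the dose

A few compounds are considered here, and "the series" means these few. Any claim that something is new, unique, unknown or untested is made for them only; others in the source may bear on it.

Measured so far:
compound 1 `C/C(C(=O)NC1CC1)=C(/C)c1cccc(C(F)(F)F)c1`: 17.4 mg/kg
compound 2 `C/C(C(=O)NC1CC1)=C(/C)c1ccc(Cl)cc1`: 11.4 mg/kg

Both compounds share the same core and were tested in a functional assay on the whole organism with Mus musculus as the target; on this read-out lower numbers stand for an effect already at smaller amounts and higher numbers for an effect only at larger amounts of compound. In this assay compound 1 gives 17.4 mg/kg and compound 2 gives 11.4 mg/kg. Of the two numbers, that of compound 2 is the lower one, but the gap to compound 1 lies within the scatter of repeated measurements, so the two are best read as alike. Going by the values given here, no step between two measured compounds that differ in a single place has been recorded, so nothing yet shows how much a small change on the aromatic ring moves the dose.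

Compound 3 `C/C(C(=O)NC1CC1)=C(/C)c1ccccc1` has not been measured. It differs from compound 2 in one place: hydrogen in place of chloro on an aromatic carbon. The two measured compounds give no direct guide for this change, so the expectation rests on the fact that the remaining pair of values is close. A step from compound 2 to compound 3 of a 1.4-fold higher number from compound 2 to compound 3 (0.15 log units; within the scatter) towards a somewhat higher dose is expected, modest and possibly still within the scatter. Compound 3 is expected to give 16 mg/kg in this assay, with a range from 8 mg/kg to 40 mg/kg.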

Compound 3, dose for half-maximal effect: 55.9 mg/kg
Compound 3: middle estimate off by 3.5-fold (0.54 log units), on the low side; measured number above the stated range.
By their numbers in this assay, from the lowest: compounds 2 and 1 (each within the scatter of the next); then compound 3.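

In this assay the group on the aromatic ring proves to matter: hydrogen in place of chloro gives a 4.9-fold higher number from compound 2 to compound 3 (0.69 log units; beyond the scatter) and hydrogen in place of trifluoromethyl gives a 3.2-fold higher number from compound 1 to compound 3 (0.51 log units; beyond the scatter) in the same direction. Compound 3, with neither group, thus needs a larger dose than compound 1 or compound 2, and both steps lie beyond the scatter, so these are the first single-place changes here shown to move the number clearly. Nothing available explains why either group makes this difference, so the steps stand as observations only.

The compounds shown leave open whether another group on the same aromatic carbon, such as fluoro, methoxy or an amine, would also give a dose lower than that of compound 3. They also leave open whether chloro would do the same on a different carbon of the ring, since here it appears only para to a large group.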